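This account rests on a few compounds, and the source may have more. Where it says the series, first, only, none or still open, it means among the compounds named here.

Measured so far:

compound 1 `COc1cc(C(=N)N)ccc1-c1cc2ccc(C(=N)N)cc2o1` — in an ADME assay on L6 cells (Rattus norvegicus) for cytotoxicity (on this read-out higher numbers stand for weaker inhibition and lower numbers for stronger inhibition), compound 1 gives 108000 nM
compound 2 `COc1ccc(C(=N)N)cc1-c1cc2ccc(C(=N)N)cc2o1` — compound 2 gives 128000 nM
compound 3 `N=C(N)c1ccc(-c2cc3ccc(C(=N)N)cc3o2)c(O)c1` — compound 3 reaches only a limit of this assay, > 221000 nM

Compounds 1 and 2 share the same atoms joined differently; the difference between the two cores is not broken down here. Their two numbers lie within the scatter of each other.

For the measured compounds named here, the one measured step is hydrogen in place of methyl on an oxygen on an aromatic ring. It gave an at least 2.0-fold higher number from compound 1 to compound 3 (0.31 log units; beyond the scatter), the end point being a limit, as noted in the limit of > 221000 nM in this assay, at which 1 of the 3 values shown sits, so the true size of the step is not known beyond its lower bound.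

Compound 4 `N=C(N)c1ccc(O)c(-c2cc3ccc(C(=N)N)cc3o2)c1` is not yet measured. It differs from compound 2 by hydrogen in place of methyl on an oxygen on an aromatic ring, the same change as from compound 1 to compound 3, at a place described in the same words.

For compound 4 in this assay a step of a 2.0-fold higher number from compound 2 to compound 4 (0.31 log units; beyond the scatter) is expected, resting on the measured step of an at least 2.0-fold higher number from compound 1 to compound 3 (0.31 log units; beyond the scatter) and on the starting point of compound 2 at 128000 nM. The estimate for compound 4 is 260000 nM, with a range from 130000 nM to 520000 nM; a result reported only as a limit is quite possible.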

Compound 4, half-maximal inhibitory concentration: 164000 nM
Compound 4: middle estimate off by 1.6-fold (0.20 log units), on the high side; the range from low to high includes it.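

On the core of compound 2, methoxy to hydroxy in this assay gives a 1.3-fold higher number from compound 2 to compound 4 (0.11 log units; within the scatter), so on this core the change does not move the number past the scatter. Set beside the step on the core of compound 1, this result does not settle whether the change carries over from one core to the other with the same size: the same change on two cores in this assay, an at least 2.0-fold higher number (0.31 log units; beyond the scatter) from compound 1 to compound 3 and a 1.3-fold higher number (0.11 log units; within the scatter) from compound 2 to compound 4; the limit leaves it open whether they differ Compound 3 gives > 221000 nM, which is a limit and not a number, so the two cores show no firm size for the change and give no basis for a rule across the series.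

The compounds shown carry only methoxy or hydroxy at this place, so what an ethoxy group, an amine or a carboxylic acid would do there in this assay stays open. Also open, from the compounds shown here alone, is whether methoxy to hydroxy would give a step of similar size on a third core.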